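The compounds below may be only part of what the source reports. "The series", "measured", "known", "first", "only" and "open" are said of these compounds alone.

Of the compounds shown here, two carry a measured value so far. Compound 1 `N#Cc1cc(Cl)ccc1NC(=O)c1ccc2cccnc2c1O` was tested in a functional assay on HL-60 cells (Homo sapiens) for cytotoxicity, read by luminescence and CellTiter-Glo, with a stated time of 3 days (on this read-out lower numbers stand for stronger inhibition and higher numbers for weaker inhibition), where compound 1 gives 790 nM. Compound 2 `O=C(Nc1ccc(C(F)(F)F)cc1)c1cc(Br)ccc1O` was run in the same way, and in this assay compound 2 gives 580 nM. Compound 2 thus holds the lower of the two numbers, but the gap to compound 1 is within the scatter of this read-out, so the two cannot be told apart with any confidence.

The next compound, compound 3 `N#Cc1ccc(NC(=O)c2cc(Br)ccc2O)cc1`, has not yet been measured. It differs from compound 2 in one place: cyano in place of trifluoromethyl on an aromatic carbon. The change sits on an aromatic carbon of a six-membered aromatic ring of carbon only, para to a large group. Among the measured compounds shown here, no measured pair shows what this exchange does, and the two numbers at hand give no trend to lean on. The expected step of a 1.5-fold higher number from compound 2 to compound 3 (0.17 log units; within the scatter) is therefore small, either none beyond the scatter or a slight move toward a higher number. For compound 3 the estimated value in this assay is 850 nM, with a range from 250 nM to 2800 nM.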

Compound 3, half-maximal inhibitory concentration: 620 nM
The estimate for compound 3 lay 1.4-fold (0.14 log units) above the measured number; low and high end bracket the measured number.
By their numbers in this assay, from the lowest: compounds 2, 3 and 1 (each within the scatter of the next).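

Among the compounds shown here, the exchange of trifluoromethyl for cyano gives the first pair here that differs in one place, and in this assay it amounts to a 1.1-fold higher number from compound 2 to compound 3 (0.03 log units; within the scatter). On this aromatic carbon, para to a large group, a group of 4 heavy atoms and no hydrogen-bond acceptor can therefore give way to one of 2 heavy atoms and 1 hydrogen-bond acceptor without a shift that this read-out can separate from its scatter. The compounds shown come with no further measurement that could account for this result.

As far as these compounds go, what the position accepts beyond these two groups remains open, since a single exchange cannot show whether an amine, a carboxylic acid or a longer alkyl chain in the same place would also leave the number within the scatter. For the compounds shown here, it is also open whether cyano in place of trifluoromethyl would read the same way on the core of compound 1, which has no one-place step to either compound 2 or compound 3.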